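From Bromo to Butyl: Expecting a Modest Shift

The source may report more compounds than this note shows. Statements on the series, on what has been measured and on what is new or still open speak of the compounds shown alone.

Of the compounds shown here, two have been measured in an assay on K177 cells for activation of Neuronal acetylcholine receptor; alpha4/beta2 (Homo sapiens); a lower number here means that less compound is needed, a higher number that more compound is needed for the effect. Compound 1 `CN1CCC[C@H]1COc1cnccc1Br` reaches only a limit of the assay, giving > 1000000 nM. Among the compounds with values here, that limit, (the limit of > 1000000 nM in this assay, at which 1 of the 2 values shown sits), is the one value standing beside a single real number. Within the data shown here, compound 2 `CN1CCC[C@H]1COc1cncc(Br)c1` gives 5950 nM in this assay, and as the only number on record it is the sole point of comparison for anything new.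

Compound 3 `CCCCc1cncc(OC[C@@H]2CCCN2C)c1` is the next candidate, still unmeasured in this assay. It differs from compound 2 in one place: butyl in place of bromo on an aromatic carbon. Among the measured compounds shown here, no measured pair shows what such a change does here, so the expectation rests on the number for compound 2 alone. With nothing pointing toward a gain, the step is expected to be modest, leaning toward needing somewhat more compound rather than less, and possibly no larger than the ordinary scatter. Compound 3 is therefore estimated at 10000 nM, within a range from 2000 nM to 50000 nM, which corresponds to an expected step of a 1.7-fold higher number from compound 2 to compound 3 (0.23 log units; within the scatter).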

Compound 3, half-maximal effective concentration: > 1000000 nM
Compound 3 gave a limit, no number (the forecaster's own chance of this, stated with the estimate: 20%); at least 100-fold (2.00 log units) between middle value and limit.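

In this assay, this position on the ring, two atoms from the ring nitrogen, proves far from indifferent to what it carries: replacing bromo with butyl gives an at least 160-fold higher number from compound 2 to compound 3 (2.22 log units; beyond the scatter). Before this result, the only contrast on record was the one between compound 1 and compound 2, which showed nothing about swapping one group for another on this carbon, and the change from a single bromine atom to a chain of four carbons now turns out to be anything but modest. Compound 2 is now the only one of the three compounds that gives a real number, and compound 3 joins compound 1 at the assay limit: the limit of > 1000000 nM in this assay, at which 2 of the 3 values shown sit.

On these data alone, what remains open is how a shorter chain such as methyl or ethyl, a single chlorine atom, or an amine would behave on this same carbon, so it cannot yet be said how much of a chain this position accepts. With only bromo and butyl shown here, two groups mark the ends of a single comparison and do not yet make a trend.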